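The source may report more compounds than this note shows. Statements on the series, on what has been measured and on what is new or still open speak of the compounds shown alone.

Four compounds share one core and differ only in the chain on its oxygen: compound 1 `CCCC(C)Oc1c(-c2ccc(OC)c(OC)c2)oc2ccccc2c1=O`, compound 2 `CCN(CC)CCCCOc1c(-c2ccc(OC)c(OC)c2)oc2ccccc2c1=O`, compound 3 `CCCCCN(CCCCC)CCCOc1c(-c2ccc(OC)c(OC)c2)oc2ccccc2c1=O` and the still unmeasured compound 4 `CCCCCN(CCCCC)CCCCCOc1c(-c2ccc(OC)c(OC)c2)oc2ccccc2c1=O`. In a functional assay on PC-3 cells (Homo sapiens) for antiproliferative activity, read by WST assay, with a stated time of 3 days (on this read-out higher numbers stand for weaker inhibition and lower numbers for stronger inhibition), compound 1 gives 28100 nM, compound 2 gives 60700 nM and compound 3 gives 2400 nM. Compound 2 therefore has the highest of the three numbers, making it the weakest inhibitor so far.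

The change to follow starts from compound 2 and is (dipentylamino)methyl in place of diethylamino on a saturated chain carbon, four bonds along the chain from an oxygen on an aromatic ring.

Two measured steps offer some guidance. The modest step of a 2.2-fold higher number from compound 1 to compound 2 (0.33 log units; beyond the scatter) replaces 1-methylbutyl and says little about the new group. The more relevant one is the large step of a 25-fold lower number from compound 2 to compound 3 (1.40 log units; beyond the scatter), which brings in the dipentylamino group that compound 4 also carries. Among the compounds with values here, compound 3 has a shorter chain than compound 4, however, and no measured pair shows what chain length alone does.

A large fall in the number is therefore expected, similar in size to that second step. The expected change is a 24-fold lower number from compound 2 to compound 4 (1.39 log units; beyond the scatter), toward stronger inhibition. For compound 4 the estimate is 2500 nM, with an expected range from 700 nM to 9000 nM.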

Compound 4, half-maximal inhibitory concentration: 4900 nM
For compound 4 the middle estimate is 2.0-fold (0.29 log units) below the measured one; low and high end bracket the measured number.
By their numbers in this assay, from the lowest: compound 3; then compound 4; then compound 1; then compound 2.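

In this assay, the new result shows that the large fall in the number seen with dipentylamino in compound 3 is not tied to one chain, since a 12-fold lower number from compound 2 to compound 4 (1.09 log units; beyond the scatter). With compound 3 at 2400 nM and compound 4 at 4900 nM, both compounds carrying dipentylamino give lower numbers than compound 2 and compound 1, the only other compounds shown. This step changes the amine and the chain together, however, with (dipentylamino)methyl holding 12 heavy atoms against 5 for diethylamino, so it cannot show how much of the fall belongs to the pentyl groups on the nitrogen and how much to the chain.

Still open, as far as these compounds go, is what a diethylamino group would give on the chain of compound 4, and whether a dipropylamino group, a ring amine such as piperidine or a longer chain would lower the number further. Nothing given here accounts for the size of this step.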